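Cytotoxicity notes: aryl substituent swap on the shared core

This account rests on a few compounds, and the source may have more. Where it says the series, first, only, none or still open, it means among the compounds named here.

Compound 3 `Cn1cnnc1-c1cccc(NC(=O)C2CCCN(C(=O)c3cc(C(F)(F)F)cc(C(F)(F)F)c3)C2)c1` gives 0% in an ADME assay on PC-3 cells (Homo sapiens) for cytotoxicity, read by WST assay, tested at 100 uM (on this read-out higher numbers stand for more inhibition at the one concentration tested (going by the name of the read-out) and lower numbers for less inhibition), level with compound 1 `O=C(Nc1cccc(N2CCCC2=O)c1)C1CCCN(C(=O)c2cc(C(F)(F)F)cc(C(F)(F)F)c2)C1` at 0% and with compound 2 `CC(=O)c1cccc(NC(=O)C2CCCN(C(=O)c3cc(C(F)(F)F)cc(C(F)(F)F)c3)C2)c1` at 0%. Compound 4 `COc1cccc(NC(=O)C2CCCN(C(=O)c3cc(C(F)(F)F)cc(C(F)(F)F)c3)C2)c1` differs from compound 3 by methoxy in place of 4-methyl-4H-1,2,4-triazol-3-yl on an aromatic carbon. The steps that altered the same aromatic carbon bear on this change: no change at the digits printed from compound 1 to compound 3 (within the scatter) and no change at the digits printed from compound 2 to compound 3 (within the scatter), and no change at the digits printed from compound 1 to compound 2 (within the scatter) likewise stayed within the scatter. Each change so far at that aromatic carbon has left the read-out flat in this assay, so no step beyond the scatter is expected from this further exchange, no change at the digits printed from compound 3 to compound 4 (within the scatter). Compound 4 is therefore estimated to give 0% in this assay, with a range from -8% to 10%.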

Compound 4, a percentage reported as inhibition, at one concentration (the size of the read-out at that concentration, not a potency): 0%
Compound 4: the middle estimate sits on the measured number at the digits printed; low and high end bracket the measured number.
By their numbers in this assay, from the lowest: compounds 1, 2, 3 and 4 (each within the scatter of the next).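

In this assay the exchange for methoxy reads no change at the digits printed from compound 3 to compound 4 (within the scatter) and no change at the digits printed from compound 2 to compound 4 (within the scatter) and no change at the digits printed from compound 1 to compound 4 (within the scatter) at this aromatic carbon. Methoxy, a group with no ring and joined through oxygen, thus extends the flat read-out beyond the acetyl, 2-oxopyrrolidin-1-yl and 4-methyl-4H-1,2,4-triazol-3-yl groups. No evidence on hand accounts for this flat read-out.

As far as these compounds go, whether a primary amine or a carboxylic acid at this carbon would depart from this level stays open. So does whether replacing a trifluoromethyl group elsewhere on the shared core would do so.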